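Swapping the para-substituent on a weakly cytotoxic pyrazoline series

This account rests on a few compounds, and the source may have more. Where it says the series, first, only, none or still open, it means among the compounds named here.

Measured compounds:
- compound 1 `CC(=O)N1N=C(c2ccco2)CC1c1ccc(Br)cc1`: 51200 nM
- compound 2 `CC(=O)N1N=C(c2ccco2)CC1c1ccc(Cl)cc1`: 57400 nM

In a functional assay on HEp-2 cells (Homo sapiens) for cytotoxicity, read by sulforhodamine B assay, with a stated time of 48 h (a lower number here means a stronger inhibitor, a higher number a weaker inhibitor), compound 1 gives 51200 nM. Compound 2 differs from it only by chloro in place of bromo on an aromatic carbon, and in this assay compound 2 gives 57400 nM. Going by the values given here, the single step available, a 1.1-fold higher number from compound 1 to compound 2 (0.05 log units; within the scatter), lies within the scatter, so the two halogenated compounds cannot be told apart on this measurement. Compound 2 carries the highest of the two numbers, but its nearest neighbour, compound 1, is separated from it by no more than the scatter.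

Compound 3 `COc1ccc(C2CC(c3ccco3)=NN2C(C)=O)cc1` has not yet been tested in this assay. It differs from compound 2 by methoxy in place of chloro on an aromatic carbon. Among the compounds with values here, no measured step here involves a methoxy group, and the only step known, from a bromo to a chloro, was flat, so there is no basis for expecting a move in either direction beyond the scatter. Compound 3 is therefore expected to give about 60000 nM, with a plausible range from 20000 nM to 180000 nM, which corresponds to an estimated step of a 1.0-fold higher number from compound 2 to compound 3 (0.02 log units; within the scatter).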

Compound 3, half-maximal inhibitory concentration: 15600 nM
Beside the measured number, compound 3's estimate is 3.8-fold (0.59 log units) above it; the whole stated range lies above it.
By their numbers in this assay, from the lowest: compound 3; then compounds 1 and 2 (each within the scatter of the next).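

The position on the aromatic ring para to a large group is not indifferent to its substituent, as the flat exchange of one halogen for the other might have suggested: in this assay, methoxy in place of chloro gives a 3.7-fold lower number from compound 2 to compound 3 (0.57 log units; beyond the scatter), and methoxy in place of bromo gives a 3.3-fold lower number from compound 1 to compound 3 (0.52 log units; beyond the scatter). Both steps lie beyond the scatter and agree in direction and closely in size, so compound 3 stands as the most potent of the three, though each step is only modest. No measurement shown here accounts for this shift, and the change in the group is all that can be stated.

On these data alone, with only bromo, chloro and methoxy at this position, it remains open whether the lower number would persist or go further with a hydroxyl, an amine or a longer chain such as ethoxy. As far as these compounds go, it is also open whether methoxy would give a similar step at another place on the ring, or whether the step seen with these cells would hold in any other cell line.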